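The source may hold more compounds than are shown below. What is called first, only, known or untested is meant among the compounds shown, and "the series" means these compounds.

Compounds measured in an ADME assay on HEK293 cells (Homo sapiens) for cytotoxicity, read by MTT assay, with a stated time of 48 h; a lower number here means a stronger inhibitor, a higher number a weaker inhibitor:

compound 1 `COc1ccc(-c2nc(SCC(=O)c3sc(-c4ccccc4)nc3C)nc(N)c2C#N)cc1`: "not determined" (no result reported)
compound 2 `Cc1nc(-c2ccc(Cl)cc2)sc1C(=O)CSc1nc(-c2ccccc2)c(C#N)c(=O)[nH]1`: "not determined" (no result reported)
compound 3 `Cc1nc(-c2ccccc2)sc1C(=O)CSc1nc(-c2ccccc2)c(C#N)c(=O)[nH]1`: 93500 nM

Compound 1 is the starting point here, yet it has no place on the scale: for compound 1 the record reads "not determined" (no result reported), so no single number exists. Compound 2 is in the same position, with "not determined" (no result reported). Only compound 3 carries a real number, 93500 nM, and one measurement cannot show a trend.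

The compound still to be tested is compound 4 `Cc1nc(-c2ccccc2)sc1C(=O)CSc1nc(N)c(C#N)c(-c2ccccc2)n1`. The change is small and sits in one place: hydrogen in place of methoxy on an aromatic carbon. In words, hydrogen stands in place of methoxy on an aromatic carbon, so a 4-methoxyphenyl becomes a phenyl. For the measured compounds named here, no measured pair shows what this swap does in this assay, and compound 1 offers no number to step from. The expectation is therefore a step no larger than the usual scatter, with neither direction favoured. The best available anchor is compound 3 at 93500 nM, so a high number, meaning weak inhibition, is expected. The assay may also report only a limit rather than a number.

For compound 4 the estimated value is 80000 nM, with an expected range from 30000 nM to 200000 nM.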

Compound 4, half-maximal inhibitory concentration: 46700 nM
Compound 4: the middle estimate sits 1.7-fold (0.23 log units) above what was measured; the range from low to high includes it.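

For the compounds shown here, compound 4 gives 46700 nM in this assay, but compound 1 has no single number there, so no step between compound 1 and compound 4 can be read. On these data alone, what the change from 4-methoxyphenyl to phenyl does in this assay stays open. No supporting evidence bears on this result.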